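The source may report more compounds than this note shows. Statements on the series, on what has been measured and on what is new or still open speak of the compounds shown alone.

Working notes on the series. Compound 1 `O=c1[nH]/c(=N\OCCCCc2ccccc2)ccn1[C@@H]1O[C@H](COP(=O)(O)OP(=O)(O)OP(=O)(O)O)[C@@H](O)[C@H]1O` gives 251 nM in a functional assay on 1321-N1 cells for agonist activity at P2Y purinoceptor 6 (Homo sapiens), read by scintillation counting and inositol phosphate accumulation; a lower number here means that less compound is needed, a higher number that more compound is needed for the effect. Compound 2 `O=c1[nH]/c(=N\OCCCc2cccc(F)c2)ccn1[C@@H]1O[C@H](COP(=O)(O)OP(=O)(O)OP(=O)(O)O)[C@@H](O)[C@H]1O` gives 539 nM in this assay, and compound 3 `O=c1[nH]/c(=N\OCCCc2ccc(Br)cc2)ccn1[C@@H]1O[C@H](COP(=O)(O)OP(=O)(O)OP(=O)(O)O)[C@@H](O)[C@H]1O` gives 225 nM. Compound 3 shows the smallest of the three numbers, but compound 1 lies within the scatter of it (a 1.1-fold lower number from compound 1 to compound 3 (0.05 log units; within the scatter)); only compound 2 stands clearly apart (a 2.4-fold lower number from compound 2 to compound 3 (0.38 log units; beyond the scatter)).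

Compound 4 `O=c1[nH]/c(=N\OCCCc2cccc(I)c2)ccn1[C@@H]1O[C@H](COP(=O)(O)OP(=O)(O)OP(=O)(O)O)[C@@H](O)[C@H]1O` differs from compound 3 by 3-iodophenyl in place of 4-bromophenyl on a saturated chain carbon, three bonds along the chain from an oxygen. Going by the values given here, no measured pair carries a 3-iodophenyl, so the bearing steps are indirect. Benzyl to 4-bromophenyl moved little (a 1.1-fold lower number from compound 1 to compound 3 (0.05 log units; within the scatter)), benzyl to 3-fluorophenyl gave a 2.1-fold higher number from compound 1 to compound 2 (0.33 log units; beyond the scatter), and the direct exchange of 3-fluorophenyl for 4-bromophenyl gave a 2.4-fold lower number from compound 2 to compound 3 (0.38 log units; beyond the scatter). The change to compound 4 resembles that last step run backwards with a different halogen, so a modest move toward a higher number is expected in this assay, a 1.7-fold higher number from compound 3 to compound 4 (0.23 log units; within the scatter), though the unfamiliar iodine leaves the direction uncertain. Compound 4 is estimated at 380 nM, within 150 nM to 950 nM.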

Compound 4, half-maximal effective concentration: 299 nM
The estimate for compound 4 lay 1.3-fold (0.10 log units) above the measured number, and the stated range covers the measured number.
By their numbers in this assay, from the lowest: compounds 3, 1, 4 and 2 (each within the scatter of the next, the first and the last beyond it).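

In this assay, 3-iodophenyl at this place, on a saturated chain carbon, three bonds along the chain from an oxygen, cannot be told apart from 4-bromophenyl (a 1.3-fold higher number from compound 3 to compound 4 (0.12 log units; within the scatter)) or from the group in compound 1 (a 1.2-fold higher number from compound 1 to compound 4 (0.08 log units; within the scatter)). Compound 2 had stood beyond the scatter of compound 1, so a halogen-bearing 3-substituted phenyl does not in itself separate a compound from compound 1, and iodo in place of fluoro on an aromatic carbon also stays within the scatter (a 1.8-fold lower number from compound 2 to compound 4 (0.26 log units; within the scatter)). No available evidence bears on the reason for these steps.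

Between compound 3 and compound 4, the halogen and its place on the ring change together, so their separate contributions remain open. Also open, going by these compounds, is how a phenyl carrying an amine or a carboxylic acid would read here.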